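Cyclohexylmethyl to 4-methylbenzyl on the amide

A few compounds are considered here, and "the series" means these few. Any claim that something is new, unique, unknown or untested is made for them only; others in the source may bear on it.

Of the compounds shown here, two of a shared core have been measured in an assay on microsomes from liver for inhibition of 3-hydroxy-3-methylglutaryl-coenzyme A reductase (Rattus norvegicus); a lower number here means a stronger inhibitor, a higher number a weaker inhibitor. Compound 1 `CCN(Cc1ccccc1)C(=O)c1nn(-c2ccc(F)cc2)c(OC[C@@H](O)C[C@@H](O)CC(=O)O)c1C(C)C` gives 14 nM in this assay. Compound 2 `CC(C)c1c(C(=O)NCC2CCCCC2)nn(-c2ccc(F)cc2)c1OC[C@@H](O)C[C@@H](O)CC(=O)O` gives 17 nM; it carries the higher of the two numbers, but the step of a 1.2-fold higher number from compound 1 to compound 2 (0.08 log units; within the scatter) shows that the two stand within the scatter of each other. Compound 3 `Cc1ccc(CNC(=O)c2nn(-c3ccc(F)cc3)c(OC[C@@H](O)C[C@@H](O)CC(=O)O)c2C(C)C)cc1` is not yet measured. It differs from compound 2 in one place: 4-methylphenyl in place of cyclohexyl on a saturated chain carbon bound to an amide-type nitrogen. For the measured compounds named here, the only step that bears on this change is the one from compound 1 to compound 2, where the group on the amide-type nitrogen was exchanged without a shift beyond the scatter. The change to compound 3 is another exchange at the same place, so no step beyond the scatter is expected in this assay, in either direction. The expected step is a 1.1-fold lower number from compound 2 to compound 3 (0.05 log units; within the scatter). The estimate for compound 3 in this assay is therefore 15 nM, within a range from 6 nM to 40 nM.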

Compound 3, half-maximal inhibitory concentration: 15 nM
Beside the measured number, compound 3's estimate shows no gap at the digits printed; low and high end bracket the measured number.
By their numbers in this assay, from the lowest: compounds 1, 3 and 2 (each within the scatter of the next).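

In this assay, the exchange of a six-membered non-aromatic ring for a six-membered aromatic ring on the saturated chain carbon bound to an amide-type nitrogen gives a 1.1-fold lower number from compound 2 to compound 3 (0.05 log units; within the scatter), so this change of ring type does not move the number beyond the scatter. The methyl group of 4-methylphenyl enters in the same step, and its share cannot be separated from that of the ring change. (4-Methylbenzyl)amino in place of benzyl(ethyl)amino on the carbonyl carbon gives a 1.1-fold higher number from compound 1 to compound 3 (0.03 log units; within the scatter), which leaves the three amide groups shown unseparated in this assay.

The compounds shown leave open whether a longer chain, such as 2-phenylethyl, would also stay within the scatter. They also leave open what a carboxylic acid or an amine in place of the 4-methyl group would do. Nothing on hand accounts for these results.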